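The source may report more compounds than this note shows. Statements on the series, on what has been measured and on what is new or still open speak of the compounds shown alone.

Measured so far in a functional assay on HCT-116 cells (Homo sapiens) for inhibition, read by MTT assay, with a stated time of 48 h; a lower number here means a stronger inhibitor, a higher number a weaker inhibitor:
- compound 1, `c1ccc(CSc2nnc(-c3ccncc3)n2-c2ccccc2)cc1`, gives 16900 nM
- compound 2, `O=C(CSc1nnc(-c2ccncc2)n1-c1ccccc1)N/N=C/c1ccccc1`, gives 14700 nM

Compound 2 holds the lowest of the two numbers in this assay, but its nearest neighbour is compound 1 and the gap between them lies within the scatter, so the two cannot be told apart on potency. Both sit at the weak end of what the read-out resolves.

The next compound, compound 3, `O=C(CSc1nnc(-c2ccncc2)n1-c1ccccc1)N/N=C/c1ccc(Cl)cc1`, keeps the whole of compound 2 and adds one substituent. The change is chloro in place of hydrogen on an aromatic carbon. The ring carrying it is the six-membered aromatic ring of carbon only at the hydrazone end; the chloro sits on an aromatic carbon of that ring, para to a large group.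

For the measured compounds named here, no pair of measured compounds shares this change, so the size of the step has no precedent in this assay. With only compound 1 and compound 2 to go on, and those two within the scatter of each other, the expectation is for a step of no more than the usual scatter, in either direction, for the move from compound 2 to compound 3.

The estimate for compound 3 in this assay is 11000 nM, with a range from 4000 nM to 30000 nM, which means an expected step of a 1.3-fold lower number from compound 2 to compound 3 (0.13 log units; within the scatter).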

Compound 3, half-maximal inhibitory concentration: 5740 nM
The estimate for compound 3 lay 1.9-fold (0.28 log units) above the measured number, and the stated range covers the measured number.
By their numbers in this assay, from the lowest: compound 3; then compounds 2 and 1 (each within the scatter of the next).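

In this assay, the aromatic ring at the hydrazone end is the one place shown where a single change can be read: chloro in place of hydrogen on an aromatic carbon, para to a large group, gives a 2.6-fold lower number from compound 2 to compound 3 (0.41 log units; beyond the scatter), a modest step. This shows that the number responds to substitution at this position and that the chloro is tolerated there, which compound 2 alone could not show, although compound 3 at 5740 nM is still a weak inhibitor. The finding rests on this single pair, and no measurement on hand gives a cause for the step.

On these data alone, whether this step is particular to chloro stays open, as does whether a methoxy, a fluoro, an amine or a carboxylic acid at the same place would move the number the same way, further or not at all. Also open, as far as these compounds go, is whether chloro on another aromatic carbon of this ring would give a step of similar size.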